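Swapping fluoro for ethoxy at a weakly active quinoline carboxamide

A few compounds are considered here, and "the series" means these few. Any claim that something is new, unique, unknown or untested is made for them only; others in the source may bear on it.

Two measured compounds share one core and differ at a single aromatic carbon. Compound 1 `CCc1ccc2nc(C(=O)Nc3c(F)cc(-c4cccc(F)c4)cc3F)c(C)c(O)c2c1` gives 3.56% in a functional assay on A-375 cells (Homo sapiens) for antiproliferative activity, read by MTT assay, with a stated time of 24 h, tested at 0.41 ug/mL; a lower number here means a weaker effect, a higher number a stronger effect of the compound at the concentration tested. Compound 2 `Cc1c(C(=O)Nc2c(F)cc(-c3cccc(F)c3)cc2F)nc2ccc(F)cc2c1O` gives 0.86% in this assay, and the change a number 2.7 percentage points lower from compound 1 to compound 2 (within the scatter) is too small to read as a real shift. Compound 2 therefore stands at the lower of the two numbers, with compound 1 alongside it within the scatter.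

Compound 3 `CCOc1ccc2nc(C(=O)Nc3c(F)cc(-c4cccc(F)c4)cc3F)c(C)c(O)c2c1` is the next variation at the same site: ethoxy in place of fluoro on an aromatic carbon. For the measured compounds named here, the only measured step that bears on this carbon, a number 2.7 percentage points lower from compound 1 to compound 2 (within the scatter), shows that replacing one group by another there left the read-out essentially unchanged and near the floor. On that basis compound 3 is expected to remain near the two measured values, with a number 2.1 percentage points higher from compound 2 to compound 3 (within the scatter) as the estimated shift, not beyond the scatter. The estimate for compound 3 is 3%, in the range 0% to 12%.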

Compound 3, a percentage reported as inhibition, at one concentration (the size of the read-out at that concentration, not a potency): 2.05%
Compound 3: middle estimate off by 1 percentage points, on the high side, and the stated range covers the measured number.
By their numbers in this assay, from the lowest: compounds 2, 3 and 1 (each within the scatter of the next).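

At this aromatic carbon, ethoxy now joins ethyl and fluoro, and this assay does not separate the three: the swap from fluoro gives a step (a number 1.2 percentage points higher from compound 2 to compound 3 (within the scatter)), and the swap from ethyl gives another (a number 1.5 percentage points lower from compound 1 to compound 3 (within the scatter)). Ethoxy brings three heavy atoms in place of the single fluorine, one of them an oxygen counted as a hydrogen-bond acceptor, and even this change produces no step beyond the scatter. No measurement at hand explains why these swaps leave no readable step.

From the compounds shown here alone, whether any group at this carbon can raise the read-out clear of these low numbers stays open; an amine, a carboxylic acid or a chain longer than ethoxy would test that. With all three compounds this low at a single concentration, the compounds shown cannot tell whether this position matters for the effect at all.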